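The source may report more compounds than this note shows. Statements on the series, on what has been measured and on what is new or still open speak of the compounds shown alone.

Measured in a functional assay on PC-3 cells (Homo sapiens) for inhibition, read by sulforhodamine B assay; on this read-out higher numbers stand for weaker inhibition of growth and lower numbers for stronger inhibition of growth:
- Compound 1 `c1ccc(-c2ccc(-c3ccc(-c4nc5ccccc5[nH]4)cc3)cc2)cc1`: 41200 nM
- Compound 2 `FC(F)(F)Oc1ccc(-c2ccc(-c3ccc(-c4nc5ccccc5[nH]4)cc3)cc2)cc1`: 100000 nM

Of these two, compound 2 stands highest, at 100000 nM, and so is the weaker growth inhibitor. Compound 3 `Oc1ccc(-c2ccc(-c3ccc(-c4nc5ccccc5[nH]4)cc3)cc2)cc1` differs from compound 2 by hydrogen in place of trifluoromethyl on an oxygen on an aromatic ring, which reads as trifluoromethoxy to hydroxy: hydrogen in place of trifluoromethyl on an oxygen on an aromatic ring. Among the measured compounds shown here, one measured step bears on this, the placing of trifluoromethoxy in place of hydrogen on an aromatic carbon, a 2.4-fold higher number from compound 1 to compound 2 (0.39 log units; beyond the scatter). That step is modest, and it does not exchange the same two groups, so it guides only loosely. A modest move towards a lower number is therefore expected in this assay. The expected step is a 2.9-fold lower number from compound 2 to compound 3 (0.46 log units; beyond the scatter). For compound 3 the estimated value is 35000 nM, with an expected range from 9000 nM to 100000 nM.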

Compound 3, concentration for 50% growth inhibition: 47000 nM
For compound 3 the middle estimate is 1.3-fold (0.13 log units) below the measured one, and the stated range covers the measured number.
By their numbers in this assay, from the lowest: compounds 1 and 3 (each within the scatter of the next); then compound 2.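

In this assay, hydrogen in place of trifluoromethyl on the oxygen gives a 2.1-fold lower number from compound 2 to compound 3 (0.33 log units; beyond the scatter), so the group carried on this oxygen does matter, though the size of the step is modest. Set against the parent, hydroxy in place of hydrogen on the aromatic carbon gives a 1.1-fold higher number from compound 1 to compound 3 (0.06 log units; within the scatter), so compound 1 and compound 3 cannot be told apart, and among these three substituent states only the trifluoromethoxy of compound 2 stands apart. Nothing available explains why trifluoromethoxy and hydroxy differ here.

From the compounds shown here alone, it remains open whether an amine or a carboxylic acid on this aromatic carbon would bring the number below those of compound 1 and compound 3. Going by these compounds, it is equally open whether methoxy, with a methyl on the same oxygen, would fall with compound 3 or with compound 2.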